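The source may hold more compounds than are shown below. What is called first, only, known or untested is meant among the compounds shown, and "the series" means these compounds.

Measured so far in a functional assay on NCI-H460 cells (Homo sapiens) for antiproliferative activity, read by MTT assay, with a stated time of 72 h; a higher number here means a weaker inhibitor, a lower number a stronger inhibitor:
Compound 1, `CN(C)CCn1cnnc1-c1cc(Oc2ccc(NC(=O)Nc3ccc(Cl)c(C(F)(F)F)c3)cc2F)ccn1`: 1150 nM
Compound 2, `CCN(CC)CCn1cnnc1-c1cc(Oc2ccc(NC(=O)Nc3ccc(Cl)c(C(F)(F)F)c3)cc2F)ccn1`: 850 nM

Compound 2 and compound 1 differ only in the amine on the chain, and the step of a 1.4-fold lower number from compound 1 to compound 2 (0.13 log units; within the scatter) lies within the scatter, so the two numbers cannot be told apart. Compound 3, `CCN(CC)CCn1cnnc1-c1cc(Oc2ccc(NC(=O)Nc3ccccc3C(F)(F)F)cc2F)ccn1`, changes a different part: 2-(trifluoromethyl)phenyl in place of 4-chloro-3-(trifluoromethyl)phenyl on an amide-type nitrogen. No measured step touches this end of the molecule, so nothing shown speaks to the size of the effect. Compound 3 is therefore expected near compound 2, with a wide range and a lean toward a higher number: a 3.5-fold higher number from compound 2 to compound 3 (0.55 log units; beyond the scatter), giving an estimate of 3000 nM (800 nM to 12000 nM).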

Compound 3, half-maximal inhibitory concentration: > 50000 nM
Compound 3 was reported as a limit; the forecaster's own chance of this, stated with the estimate: 5%; middle value at least 16-fold (1.22 log units) from the limit.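

Placing 2-(trifluoromethyl)phenyl instead of 4-chloro-3-(trifluoromethyl)phenyl on the amide-type nitrogen gives an at least 58-fold higher number from compound 2 to compound 3 (1.76 log units; beyond the scatter). Compound 3 stands at a limit, not at a true number: the limit of > 50000 nM in this assay, at which 1 of the 3 values shown sits. So this end of the molecule can matter greatly, whereas the amine change gave only a 1.4-fold lower number from compound 1 to compound 2 (0.13 log units; within the scatter).

This single swap both removes the chlorine and changes the substitution pattern of the trifluoromethyl group, so the compounds shown cannot separate those two changes. From the compounds shown here alone, how a plain phenyl group, or a phenyl carrying chlorine alone, would fare on that nitrogen stays open.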